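Two Fluorines for Two Chlorines on a Carbonyl Carbon

The source may report more compounds than this note shows. Statements on the series, on what has been measured and on what is new or still open speak of the compounds shown alone.

Compound 1: `COc1ccc(-c2cc(/C=C/C(=O)c3ccc(N)cc3)[nH]n2)cc1` — -26%
Compound 2: `COc1cc(-c2cc(/C=C/C(=O)c3ccc(Cl)c(Cl)c3)[nH]n2)cc(OC)c1OC` — 47%

In a functional assay on SW-620 cells (Homo sapiens) for cytotoxicity, read by sulforhodamine B assay, with a stated time of 48 h, tested at 10 uM (a higher number here means a weaker effect of the compound at the concentration tested, a lower number a stronger effect), compound 2 gives 47%, the highest of the two numbers measured. Compound 1 gives -26%, a number lower by a margin beyond the usual scatter, so compound 1 shows the stronger effect at the concentration tested. Among the compounds with values here, these two compounds differ in more than one place, and no single step connects them; their two values say only that much.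

Compound 3 is `COc1cc(-c2cc(/C=C/C(=O)c3ccc(F)c(F)c3)[nH]n2)cc(OC)c1OC`. Set against compound 2, it carries 3,4-difluorophenyl in place of 3,4-dichlorophenyl on a carbonyl carbon. No step of this kind has been measured among these compounds. Swapping the 3,4-dichlorophenyl for the 3,4-difluorophenyl is expected to move the number little, and the step of a number 8 percentage points higher from compound 2 to compound 3 (within the scatter) is expected to stay within the scatter, leaning if anything toward a higher number. Compound 3 is therefore estimated to give 55% in this assay, within a range from 25% to 85%.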

Compound 3, a percentage reported as activity, at one concentration (the size of the read-out at that concentration, not a potency): 12%
Beside the measured number, compound 3's estimate is 43 percentage points above it, outside the stated range (below it).
By their numbers in this assay, from the lowest: compound 1; then compound 3; then compound 2.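

In this assay the change from 3,4-dichlorophenyl to 3,4-difluorophenyl on a carbonyl carbon gives a number 35 percentage points lower from compound 2 to compound 3 (beyond the scatter) and so places the stronger effect at the concentration tested with the difluorinated compound. This is the first comparison among these compounds that turns on one place, and it shows that the number at this position responds to which atoms the ring carries, even though the two groups match in heavy atoms, rings, hydrogen-bond donors and acceptors, and charge. Nothing available here accounts for the size of this step.

The compounds shown leave open how an unsubstituted phenyl, or a phenyl bearing a nitrile or a carboxylic acid, would read at this carbonyl carbon in this assay and whether the same swap would move the number as far on the core of compound 1.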